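Bromo for methoxy on the chloropyridine core

The source may hold more compounds than are shown below. What is called first, only, known or untested is meant among the compounds shown, and "the series" means these compounds.

Compound 2 `COc1cc(N2CCCNCC2)cnc1Cl` gives 91.2 nM in a functional assay on HEK293 cells for agonist activity at Neuronal acetylcholine receptor; alpha4/beta2 (Homo sapiens), read by FLIPR and calcium flux (on this read-out higher numbers stand for an effect only at larger amounts of compound and lower numbers for an effect already at smaller amounts), the lowest of the three numbers shown. Compound 1 `Clc1cncc(N2CCCNCCC2)c1` gives 170 nM in this assay, a gap to compound 2 that stays within the scatter. Compound 3 `c1ccc2ncc(N3CCCNCC3)cc2c1` gives 3630 nM in this assay, a gap to compound 2 that lies beyond the scatter. Compound 4 `Clc1ncc(N2CCCNCC2)cc1Br` differs from compound 2 by bromo in place of methoxy on an aromatic carbon, on an aromatic carbon of a six-membered aromatic ring with 1 nitrogen, ortho to a chloro group. Among the measured compounds shown here, no measured pair shows this change, so the step is expected to be small, at most a modest move toward a higher number. For compound 4 the expected value is 150 nM with a range of 40 nM to 600 nM. The step this expects from compound 2 to compound 4 is a 1.6-fold higher number from compound 2 to compound 4 (0.22 log units; within the scatter).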

Compound 4, half-maximal effective concentration: 57.5 nM
The estimate for compound 4 lay 2.6-fold (0.42 log units) above the measured number; low and high end bracket the measured number.
By their numbers in this assay, from the lowest: compounds 4, 2 and 1 (each within the scatter of the next, the first and the last beyond it); then compound 3.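

In this assay, bromo in place of methoxy on an aromatic carbon gives a 1.6-fold lower number from compound 2 to compound 4 (0.20 log units; within the scatter) and so stays within the scatter, which means this position, ortho to a chloro group, accepts either group without a step beyond it. Among the compounds shown here, this is the first pair that differs in one place, so the earlier compounds gave no reading of this position. No evidence at hand accounts for the result.

Still open, as far as these compounds go, is how an amine, a carboxylic acid or a longer chain would fare at this position. Also open, from the compounds shown here alone, is whether fluoro or a plain hydrogen there would keep the number in the same range.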